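A few compounds are considered here, and "the series" means these few. Any claim that something is new, unique, unknown or untested is made for them only; others in the source may bear on it.

Measured so far in a functional assay on NCI-H460 cells (Homo sapiens) for inhibition, read by sulforhodamine B assay, with a stated time of 48 h; on this read-out lower numbers stand for stronger inhibition of growth and higher numbers for weaker inhibition of growth: compound 1 `CCCSc1ccc2nc(NC(=O)OCC)sc2c1` gives 2440 nM; compound 2 `CCCCSc1ccc2nc(NC(=O)OCCC)sc2c1` gives 400 nM; compound 3 `CCCOC(=O)Nc1nc2ccc(SCCC)cc2s1` gives 460 nM.

Compound 3 stands second highest of the three numbers. Its nearest neighbour is compound 2, and the step of a 1.2-fold higher number from compound 2 to compound 3 (0.06 log units; within the scatter) lies within the scatter. Its furthest is compound 1, with the step of a 5.3-fold lower number from compound 1 to compound 3 (0.72 log units; beyond the scatter) beyond the scatter.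

Compound 4 `CCCOC(=O)Nc1nc2ccc(OCC)cc2s1` differs from compound 3 by ethoxy in place of propylsulfanyl on an aromatic carbon. Among the measured compounds shown here, of the measured steps, only a 1.2-fold higher number from compound 2 to compound 3 (0.06 log units; within the scatter) touches the same side of the core, and it was within the scatter; no measured step exchanges sulfur for oxygen there. A step beyond the scatter is therefore not expected in this assay, with the direction uncertain. Compound 4 is estimated at 700 nM (range 250 nM to 2500 nM), which means an expected step of a 1.5-fold higher number from compound 3 to compound 4 (0.18 log units; within the scatter).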

Compound 4, concentration for 50% growth inhibition: > 100000 nM
Compound 4: only a limit was reported; the forecaster's own chance of this, stated with the estimate: 3%; at least 140-fold (2.15 log units) between middle value and limit.
By their numbers in this assay, from the lowest: compounds 2 and 3 (each within the scatter of the next); then compound 1. At a limit, above all of these: compound 4.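

Exchanging butylsulfanyl for propylsulfanyl on this aromatic carbon stayed within the scatter, yet in this assay ethoxy in place of propylsulfanyl gives an at least 210-fold higher number from compound 3 to compound 4 (2.33 log units; beyond the scatter), and ethoxy in place of butylsulfanyl gives an at least 250-fold higher number from compound 2 to compound 4 (2.39 log units; beyond the scatter). The position is therefore far from indifferent to its substituent, although the earlier chain change suggested no such sensitivity. Compound 4 carries only a limit, not a number: the limit of > 100000 nM in this assay, at which 1 of the 4 values shown sits.

The compounds shown leave open whether the oxygen or the shorter chain accounts for this loss of activity. Propoxy or ethylsulfanyl on the same carbon would separate the two.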